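The source may report more compounds than this note shows. Statements on the series, on what has been measured and on what is new or still open speak of the compounds shown alone.

Series notes. Going by the values given here, the three measured members share one core: compound 1 `C[C@@H](/N=c1\c(O)c(O)\c1=N/Cc1ccc(C#N)cc1)C(C)(C)C`, compound 2 `CC(C)/N=c1\c(O)c(O)\c1=N/Cc1ccc(C#N)cc1` and compound 3 `CC(C)(C)/N=c1\c(O)c(O)\c1=N/Cc1ccc(C#N)cc1`. In a functional assay for inhibition, with Rattus norvegicus as the target (on this read-out lower numbers stand for stronger inhibition and higher numbers for weaker inhibition), compound 1 gives 270 nM, compound 2 gives 14000 nM and compound 3 gives 270 nM. Compound 3 thus stands level with compound 1, the two together at the low end of the three numbers, with no change at the digits printed from compound 1 to compound 3 (within the scatter); compound 2 is the furthest, with a 52-fold lower number from compound 2 to compound 3 (1.71 log units; beyond the scatter). The next member is compound 4 `CCCC/N=c1\c(O)c(O)\c1=N/Cc1ccc(C#N)cc1`, which differs from compound 3 by butyl in place of tert-butyl on a double-bonded nitrogen. Among the compounds with values here, two measured steps bear on this change: a 52-fold lower number from compound 2 to compound 3 (1.71 log units; beyond the scatter) is large, and a 52-fold higher number from compound 1 to compound 2 (1.71 log units; beyond the scatter) points the same way, whereas no change at the digits printed from compound 1 to compound 3 (within the scatter) shows that a longer group on the double-bonded nitrogen is neutral when the carbon on that nitrogen keeps its branching. Within the data shown here, no measured compound carries an unbranched chain on the double-bonded nitrogen, so the step is an extrapolation. A large weakening is expected, and compound 4 is expected to give 20000 nM, between 3000 nM and 100000 nM. This corresponds to an expected step of a 74-fold higher number from compound 3 to compound 4 (1.87 log units; beyond the scatter).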

Compound 4, half-maximal inhibitory concentration: > 30000 nM
Compound 4: no number, only a limit; the forecaster's own chance of this, stated with the estimate: 25%; at least 1.5-fold (0.17 log units) between middle value and limit.
By their numbers in this assay, from the lowest: compounds 1 and 3 (each within the scatter of the next); then compound 2. At a limit, above all of these: compound 4.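

In this assay compound 4 gives > 30000 nM, which is a limit and not a number. Tert-butyl and butyl hold the same atoms joined differently, yet that change alone gives an at least 110-fold higher number from compound 3 to compound 4 (2.04 log units; beyond the scatter), and replacing 1,2,2-trimethylpropyl gives an at least 110-fold higher number from compound 1 to compound 4 (2.04 log units; beyond the scatter), so at this position the arrangement of the carbons counts and not merely their number. Isopropyl, already far behind in the earlier compounds, also differs from the unbranched chain, with an at least 2.1-fold higher number from compound 2 to compound 4 (0.33 log units; beyond the scatter), which places butyl beyond all three branched groups shown.

From the compounds shown here alone, how far compound 4 really lies past the other three stays unknown. Also open, going by these compounds, is how propyl, a longer unbranched chain, or isobutyl and neopentyl would read on the double-bonded nitrogen in this assay.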